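Nitro to methylsulfonyl: cytotoxicity remains unmeasurable

The source may report more compounds than this note shows. Statements on the series, on what has been measured and on what is new or still open speak of the compounds shown alone.

Compound 1 `CCc1ccc(-c2nc3c(c(C)nn3-c3ccccc3)c(-c3ccccc3[N+](=O)[O-])c2C#N)cc1`: in an ADME assay on BJ cells (Homo sapiens) for cytotoxicity, with a stated time of 72 h (a lower number here means that less compound is needed, a higher number that more compound is needed for the effect), compound 1 gives > 20000 nM, which is a limit of the assay rather than a number.
Compound 2 `CCc1ccc(-c2nc3c(c(C)nn3-c3ccccc3)c(-c3ccccc3S(C)(=O)=O)c2C#N)cc1`: in this assay compound 2 gives > 20000 nM, again a limit of the assay.
Compound 3 `Cc1nn(-c2ccccc2)c2nc(-c3ccc([N+](=O)[O-])cc3)c(C#N)c(-c3ccccc3O)c12`: in this assay compound 3 gives > 20000 nM, also a limit of the assay.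

Compound 1 and compound 2 differ in one place only, (methylsulfonyl in place of nitro on an aromatic carbon). The step that the two limits leave unreadable from compound 1 to compound 2 has no readable size because the limit of > 20000 nM in this assay, at which 3 of the 3 values shown sit, holds both of its ends. Compound 3 and compound 1 differ in more than one place, so the difference between the two cores is not broken down here.

Compound 4 `Cc1nn(-c2ccccc2)c2nc(-c3ccc(S(C)(=O)=O)cc3)c(C#N)c(-c3ccccc3O)c12` has not yet been measured. It differs from compound 3 by methylsulfonyl in place of nitro on an aromatic carbon. For the measured compounds named here, this is the same kind of change as the one from compound 1 to compound 2, but not the same: there the group sits ortho to a large group, here para to a large group.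

The step that the limit leaves unreadable from compound 3 to compound 4 is expected to be small, since the limit of > 20000 nM in this assay, at which 3 of the 3 values shown sit, is where every value of the three measured compounds sits, and the same kind of change left compound 1 and compound 2 both at that limit. For compound 4 the estimate in this assay is 30000 nM, expected to lie between 10000 nM and 100000 nM, with the assay most likely reporting only a limit once more.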

Compound 4, half-maximal effective concentration in the BJ assay: > 20000 nM
Compound 4: a limit, no number; the forecaster's own chance of this, stated with the estimate: 85%; the middle value lies beyond the limit too.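

In the BJ assay compound 4 gives > 20000 nM, which is a limit of the assay rather than a number. Compound 3 and compound 4 therefore have no readable step between them, since both ends are held at the same limit: the limit of > 20000 nM in the BJ assay, at which 4 of the 4 values shown sit.

The compounds shown leave open how far apart compounds 1 to 4 truly lie in this assay, and which change of group, if any, would give a measurable number.

In a physicochemical assay for solubility, read by spectrophotometry, in phosphate buffer, with a stated time of 18 h, at pH 7.4 (on this read-out higher numbers stand for higher solubility and lower numbers for lower solubility), compound 3 gives 6000 nM and compound 4 gives 5000 nM. In the physicochemical assay the change of nitro to methylsulfonyl is a 1.2-fold lower number from compound 3 to compound 4 (0.08 log units; within the scatter), so the two compounds cannot be told apart on this read-out.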